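The compounds below may be only part of what the source reports. "The series", "measured", "known", "first", "only" and "open" are said of these compounds alone.

Three compounds carry a measured number in an assay on HEK293 cells for binding affinity to 5-hydroxytryptamine receptor 7 (Homo sapiens), read by radioligand binding; on this read-out lower numbers stand for stronger inhibition and higher numbers for weaker inhibition. Compound 1 `Brc1ccc2ccn(CCN3CCN4CCCCC4C3)c2c1` gives 70 nM, and compound 2 `Brc1ccc2ccn(CCN3CCCN4CCCCC4C3)c2c1` gives 3 nM. Compound 3 `CN1CCCN(CCn2ccc3ccc(F)cc32)CC1` gives 288 nM, the highest of the three numbers; compound 1 sits nearest to it and compound 2 furthest, both gaps lying beyond the scatter. Compound 4 `CN1CCCN(CCn2ccc3ccc(C(F)(F)F)cc32)CC1` has not been measured; it differs from compound 3 by trifluoromethyl in place of fluoro on an aromatic carbon. Within the data shown here, no measured pair in the set shows this change, so nothing can be read off for its size. The move is expected to be small, a 1.4-fold lower number from compound 3 to compound 4 (0.16 log units; within the scatter), and may stay within the scatter in either direction. For compound 4 an inhibition constant of 200 nM is estimated, with a range from 50 nM to 800 nM.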

Compound 4, inhibition constant: 23 nM
Compound 4: middle estimate off by 8.7-fold (0.94 log units), on the high side, outside the stated range (below it).
By their numbers in this assay, from the lowest: compound 2; then compound 4; then compound 1; then compound 3.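

In this assay, among these compounds, trifluoromethyl in place of fluoro on this aromatic carbon gives a 13-fold lower number from compound 3 to compound 4 (1.10 log units; beyond the scatter) and so supplies the first single-place step. The position is therefore sensitive to the group it carries, and a change that adds no hydrogen-bond donors or acceptors is enough to move the number well beyond the scatter. Nothing shown accounts for the size of this step.

Open, going by these compounds, is how chloro, methyl or methoxy on the same aromatic carbon would compare with trifluoromethyl. Also open, on these data alone, is whether the same change gives a similar step on the amine side chains of compound 1 and compound 2.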